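Trading ethoxy for trifluoromethyl in compound 3

This account rests on a few compounds, and the source may have more. Where it says the series, first, only, none or still open, it means among the compounds named here.

Compound 1 (`COc1cc(C(=O)c2sc(-c3ccc(-c4ccccc4)cc3)cc2N)cc(OC)c1OC`) reads > 10000 nM in a functional assay on MOLT-4 cells (Homo sapiens) for antiproliferative activity (on this read-out higher numbers stand for weaker inhibition and lower numbers for stronger inhibition), and this is a limit, not a number. Compound 2 (`CCOc1ccc(-c2cc(N)c(C(=O)c3cc(OC)c(OC)c(OC)c3)s2)cc1`) gives 240 nM, the only actual number shown so far. Compound 3 (`COc1cc(C(=O)c2sc(-c3ccc(C(F)(F)F)cc3)cc2N)cc(OC)c1OC`) carries trifluoromethyl in place of ethoxy on an aromatic carbon. Among the measured compounds shown here, the one measured step bearing on this place, an at least 41-fold lower number from compound 1 to compound 2 (1.61 log units; beyond the scatter), is large and brought the ethoxy in, so losing that group is expected to raise the number, though probably by less. The estimated change is a 6.3-fold higher number from compound 2 to compound 3 (0.80 log units; beyond the scatter), towards weaker inhibition. For compound 3 the expected value is 1500 nM, with an estimated range of 250 nM to 9000 nM.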

Compound 3, half-maximal inhibitory concentration: 250 nM
The estimate for compound 3 lay 6.0-fold (0.78 log units) above the measured number, and the stated range covers the measured number.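

Trifluoromethyl and ethoxy cannot be told apart at this position in this assay (a 1.0-fold higher number from compound 2 to compound 3 (0.02 log units; within the scatter)), although ethoxy carries a hydrogen-bond acceptor and trifluoromethyl carries none. Phenyl is the group that stands apart so far (an at least 40-fold lower number from compound 1 to compound 3 (1.60 log units; beyond the scatter)), now against two different groups rather than one. The size of that step is only a bound because compound 1 reads as a limit, not a number: the limit of > 10000 nM in this assay, at which 1 of the 3 values shown sits.

As far as these compounds go, whether an amine, a carboxylic acid or a longer chain such as butoxy would match compound 2 and compound 3 or fall towards compound 1 remains open.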